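One Methylene More at the Aromatic Amine

The source may report more compounds than this note shows. Statements on the series, on what has been measured and on what is new or still open speak of the compounds shown alone.

Compound 1, `N#Cc1cnc(NCc2cnccc2C(F)(F)F)cc1NC[C@H]1C[C@H](O)C1`, gives 93% in an ADME assay on S9 fraction from liver (Homo sapiens) for metabolic stability, with a stated time of 1 h; on this read-out higher numbers stand for a more stable compound and lower numbers for a less stable compound.
Compound 2, `CO[C@H]1CC[C@@H](Nc2cc(NCc3cnccc3C(F)(F)F)ncc2C#N)CC1`, gives 19% in this assay.

On these two numbers compound 2 stands lowest; its nearest neighbour is compound 1, and the step of a number 74 percentage points lower from compound 1 to compound 2 (beyond the scatter) lies beyond the usual scatter. The next compound, compound 3, `CO[C@H]1CC[C@@H](CNc2cc(NCc3cnccc3C(F)(F)F)ncc2C#N)CC1`, has not yet been measured in this assay. Its change from compound 2 is (4-methoxycyclohexyl)methyl in place of 4-methoxycyclohexyl on a nitrogen on an aromatic ring.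

Within the data shown here, only one measured step bears on this at all, and only in part: a number 74 percentage points lower from compound 1 to compound 2 (beyond the scatter) exchanged both the ring and the link to the nitrogen at once, so the share belonging to the methylene alone cannot be separated from it. Compound 1, the more stable compound, does carry a methylene between its ring and the nitrogen, which is the only hint in the data. On that thin ground compound 3 is expected to give 30%, within a range of 8% to 65%. The expected step is a number 11 percentage points higher from compound 2 to compound 3 (beyond the scatter), a rise that may or may not clear the scatter.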

Compound 3, percent of the compound remaining: 4%
For compound 3 the middle estimate is 26 percentage points above the measured one; the measured number lies below the stated range.
By their numbers in this assay, from the lowest: compound 3; then compound 2; then compound 1.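

Adding one methylene to the link on the nitrogen, with the 4-methoxycyclohexyl ring kept, is the first change at this position that can be read alone, and in this assay it gives a number 15 percentage points lower from compound 2 to compound 3 (beyond the scatter). The methylene that compound 1 carries therefore does not go with stability by itself, since compound 3 has the same link and stands lowest of the three. With that link held constant, 4-methoxycyclohexyl in place of 3-hydroxycyclobutyl on a saturated chain carbon bound to a nitrogen on an aromatic ring gives a number 89 percentage points lower from compound 1 to compound 3 (beyond the scatter), so the far end of the substituent weighs much more here than the extra methylene, though nothing available explains either step.

As far as these compounds go, compound 1 and compound 3 differ in ring size and in hydroxyl against methoxy at once, so how the larger step divides between the two stays open, and a 4-hydroxycyclohexyl group on the same methylene link would speak to that. From the compounds shown here alone, whether the methylene step holds on another ring, for instance with 3-hydroxycyclobutyl bound directly to the nitrogen, also stays open.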